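The source may report more compounds than this note shows. Statements on the series, on what has been measured and on what is new or still open speak of the compounds shown alone.

Going by the values given here, in a functional assay on HL-60 cells (Homo sapiens) for antiproliferative activity, read by MTT assay, with a stated time of 72 h (a higher number here means a weaker inhibitor, a lower number a stronger inhibitor), compound 3 (`CCOc1ccc(-c2ncnn2-c2cc(OC)c(OC)c(OC)c2)cc1Cl`) gives 3 nM, the lowest of the three numbers measured so far. Compound 1 (`COc1cc(-n2ncnc2-c2ccc(C)cc2)cc(OC)c1OC`) gives 90 nM, and compound 2 (`COc1ccc(-c2ncnn2-c2cc(OC)c(OC)c(OC)c2)cc1`) gives 120 nM. Compound 4 (`COc1cc(-n2ncnc2-c2ccc(Cl)c(Cl)c2)cc(OC)c1OC`) has not yet been measured. It differs from compound 3 by one change, chloro in place of ethoxy on an aromatic carbon, ortho to a chloro group and para to a large group.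

Among the compounds with values here, no measured step makes this exact swap. The closest is a 1.3-fold higher number from compound 1 to compound 2 (0.12 log units; within the scatter), where methoxy in place of methyl stayed within the scatter, so that step offers only weak guidance. Of the measured compounds, only compound 3, at 3 nM, carries ethoxy and chloro together, so losing the ethoxy may well lose much of its lead. A large step towards a weaker inhibitor in this assay therefore seems likely, though its size is uncertain. The expected change is a 33-fold higher number from compound 3 to compound 4 (1.52 log units; beyond the scatter). For compound 4, the estimated value is 100 nM, with an expected range of 15 nM to 600 nM.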

Compound 4, half-maximal inhibitory concentration: > 10000 nM
Compound 4 was reported as a limit; the forecaster's own chance of this, stated with the estimate: 5%; middle value at least 100-fold (2.00 log units) away from the limit.
By their numbers in this assay, from the lowest: compound 3; then compounds 1 and 2 (each within the scatter of the next). At a limit, above all of these: compound 4.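

Compound 4 is reported in this assay only as a limit, not as a number: the limit of > 10000 nM in this assay, at which 1 of the 4 values shown sits. At this place on the ring, ortho to a chloro group and para to a large group, ethoxy cannot be exchanged for chloro without a very large loss, and the step is an at least 3300-fold higher number from compound 3 to compound 4 (3.52 log units; beyond the scatter). The earlier methoxy and methyl rings differed little, yet 3,4-dichlorophenyl falls far behind both, with an at least 83-fold higher number from compound 2 to compound 4 (1.92 log units; beyond the scatter) and an at least 110-fold higher number from compound 1 to compound 4 (2.04 log units; beyond the scatter), so this ring tolerates some groups and not others.

The compounds shown cannot separate harm from the added chloro from the loss of the ethoxy itself. As far as these compounds go, how a hydroxy group, an amine or a longer chain such as propoxy would fare at this place remains open, as does whether the ethoxy needs its neighbouring chloro.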